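Swapping the outer ring on a low-toxicity series

A few compounds are considered here, and "the series" means these few. Any claim that something is new, unique, unknown or untested is made for them only; others in the source may bear on it.

Compound 1 `Cc1c(Cc2ccc(OC(F)(F)F)cc2)c(=O)oc2cc(OCC(O)CN3CCC(C(N)=O)CC3)ccc12`: 68200 nM
Compound 2 `Cc1c(Cc2ccc(-c3ccc(Cl)cc3)cc2)c(=O)oc2cc(OCC(O)CN3CCC(C(N)=O)CC3)ccc12`: 32900 nM

In an ADME assay on A549 cells (Homo sapiens) for cytotoxicity, read by CellTiter-Glo (on this read-out higher numbers stand for lower toxicity in this test and lower numbers for higher toxicity in this test), compound 2 gives 32900 nM, the lower of the two numbers, so it is the more toxic of the pair. Compound 3 `Cc1c(Cc2ccc(-c3ccc(C#N)c(F)c3)cc2)c(=O)oc2cc(OCC(O)CN3CCC(C(N)=O)CC3)ccc12` has not been measured yet. It differs from compound 2 only in the outer ring: 4-cyano-3-fluorophenyl in place of 4-chlorophenyl on an aromatic carbon. This puts 4-cyano-3-fluorophenyl in place of 4-chlorophenyl on an aromatic carbon, para to a large group. Going by the values given here, one measured step bears on this change, at the same carbon: a 2.1-fold lower number from compound 1 to compound 2 (0.32 log units; beyond the scatter). That modest step exchanged trifluoromethoxy for a whole ring, whereas compound 3 keeps a ring there, so a step no larger is expected, probably within the scatter and with no firm direction. The estimated step is a 1.2-fold higher number from compound 2 to compound 3 (0.08 log units; within the scatter). For compound 3 the expected value is 40000 nM, with an estimated range of 18000 nM to 85000 nM.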

Compound 3, half-maximal cytotoxic concentration: 29100 nM
Beside the measured number, compound 3's estimate is 1.4-fold (0.14 log units) above it; measured number inside the range.
By their numbers in this assay, from the lowest: compounds 3 and 2 (each within the scatter of the next); then compound 1.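

In this assay, exchanging 4-chlorophenyl for 4-cyano-3-fluorophenyl gives a 1.1-fold lower number from compound 2 to compound 3 (0.05 log units; within the scatter) and so leaves the read-out effectively unchanged, even though the entering ring is larger and carries a nitrile and a fluorine. The earlier pair showed one ring against trifluoromethoxy with a 2.1-fold lower number from compound 1 to compound 2 (0.32 log units; beyond the scatter) as its step, and the second ring now gives a 2.3-fold lower number from compound 1 to compound 3 (0.37 log units; beyond the scatter) as its own, so both outer rings shown sit on the more toxic side of compound 1. No supporting measurement is available to explain why these two rings read alike.

The compounds shown leave open whether an outer ring bearing an amine or a carboxylic acid would stay in the same range. They also leave open whether a longer chain between the two aromatic rings would do so.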